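The source may report more compounds than this note shows. Statements on the series, on what has been measured and on what is new or still open speak of the compounds shown alone.

Among the measured compounds shown here, compound 2 `CC1CC/C(=N\Nc2ccc(C(=O)O)cc2)c2ncc(C(=O)O)c(=O)n21` gives 1000000 nM in a functional assay (mast cells) for inhibition, with Rattus norvegicus as the target (a lower number here means that less compound is needed, a higher number that more compound is needed for the effect), and so holds the higher of the two numbers measured so far. Compound 1 `CC1CC/C(=N\Nc2ccc(C(F)(F)F)cc2)c2ncc(C(=O)O)c(=O)n21` gives 280 nM there. Compound 3 `CCCCc1ccc(N/N=C2\CCC(C)n3c2ncc(C(=O)O)c3=O)cc1` differs from compound 2 by one change, (butyl in place of carboxy on an aromatic carbon), that is, butyl in place of carboxy on an aromatic carbon, para to a large group. For the measured compounds named here, one measured step bears on it: the change of trifluoromethyl to carboxy on an aromatic carbon gave a 3600-fold higher number from compound 1 to compound 2 (3.55 log units; beyond the scatter), a large step beyond the scatter. Going by the values given here, compound 3 loses that same carboxy, although no measured compound carries butyl, so a large step to a lower number is expected, close in size to that one. The estimated step is a 2000-fold lower number from compound 2 to compound 3 (3.30 log units; beyond the scatter) in this assay and would be large. For compound 3 the expected value is 500 nM, with an estimated range from 60 nM to 5000 nM as its likely span.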

Compound 3, half-maximal effective concentration: 1700 nM
For compound 3 the middle estimate is 3.4-fold (0.53 log units) below the measured one; the range from low to high includes it.
By their numbers in this assay, from the lowest: compound 1; then compound 3; then compound 2.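

In this assay, the large step seen on losing the carboxy is not tied to trifluoromethyl: butyl, which enters with only carbon atoms and no hydrogen-bond donor or acceptor, gives a 590-fold lower number from compound 2 to compound 3 (2.77 log units; beyond the scatter) at the same aromatic carbon, para to a large group. The two replacements are not interchangeable, however: butyl in place of trifluoromethyl gives a 6.1-fold higher number from compound 1 to compound 3 (0.78 log units; beyond the scatter) and leaves compound 1 with the lowest number of the three. Nothing measured here accounts for the gap between these two groups.

Only three groups are shown at this position, so it remains open which feature of the carboxy goes with the high number. Also open, on these data alone, is how an amine, a methoxy group, or a shorter or longer chain would compare with butyl and trifluoromethyl here.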